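The compounds below may be only part of what the source reports. "The series", "measured", "known", "first", "only" and "open" are said of these compounds alone.

In a functional assay on MCF7 cells (Homo sapiens) for cytotoxicity, read by MTT assay, with a stated time of 48 h (on this read-out higher numbers stand for weaker inhibition and lower numbers for stronger inhibition), the three measured compounds stand as follows.

Compound 1, `COc1cc(N2C(=S)SCC2(O)c2ccc(Cl)cc2Cl)cc(OC)c1OC`, gives 9.6 ug/mL in this assay.
Compound 2, `COc1cc(-n2c(-c3ccccc3)csc2=S)cc(OC)c1OC`, gives only a limit, > 100 ug/mL, in this assay.
Compound 3, `COc1cc(-n2c(-c3ccc(Br)cc3)csc2=S)cc(OC)c1OC`, likewise gives only a limit, > 100 ug/mL, in this assay.

Compound 3 therefore has no number of its own in this assay, only a limit. Compound 1 alone gives a readable number. For the measured compounds named here, the single step between compounds that differ in one place, a step that the two limits leave unreadable from compound 2 to compound 3, cannot be sized, because both of its ends sit at the limit of > 100 ug/mL in this assay, at which 2 of the 3 values shown sit.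

Compound 4, `COc1cc(-n2c(-c3ccc(F)cc3)csc2=S)cc(OC)c1OC`, differs from compound 3 by fluoro in place of bromo on an aromatic carbon. Going by the values given here, no measured step shows what exchanging one halogen for another does here; the only measured one-place step is unreadable, and it concerns a halogen entering in place of hydrogen rather than one halogen replacing another. For compound 4 the expected step is a step that the limit leaves unreadable from compound 3 to compound 4, and compound 4 is expected most likely to stay at the limit, as compound 3 does. Compound 4 is estimated at 150 ug/mL in this assay, within 40 ug/mL to 500 ug/mL.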

Compound 4, half-maximal inhibitory concentration: 38.5 ug/mL
Compound 4: the middle estimate sits 3.9-fold (0.59 log units) above what was measured; measured number outside the range, below it.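

In this assay, for the compounds shown here, the change from 4-bromophenyl to 4-fluorophenyl gives an at least 2.5-fold lower number from compound 3 to compound 4 (0.41 log units; beyond the scatter), showing that the group on this aromatic carbon can shift the read-out, which the earlier compounds could not show. Fluoro in place of hydrogen on the same carbon gives an at least 2.5-fold lower number from compound 2 to compound 4 (0.41 log units; beyond the scatter), so fluoro brings a readable number whether it replaces bromo or hydrogen. Both steps are minimum sizes and the real gaps may be larger, because one end of each is a limit and not a number: the limit of > 100 ug/mL in this assay, at which 2 of the 4 values shown sit.

The compounds shown leave open what a chloro group, a methoxy group or an amine on this carbon would do to the read-out. Compound 4 and compound 1 differ in more than one place, so no step can be read between them.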